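Thiophene to oxolane swap on the benzyl arm

The source may hold more compounds than are shown below. What is called first, only, known or untested is meant among the compounds shown, and "the series" means these compounds.

Measured so far in an assay on isolated protein for inhibition of ubiquitin carboxyl-terminal hydrolase 7 (Homo sapiens), with stated times of 30 min and 2 h; a higher number here means a weaker inhibitor, a lower number a stronger inhibitor:
compound 1 `Cn1nc2c(=O)n(CC3(O)CCN(Cc4ccc(-c5ccco5)cc4Cl)CC3)cnc2c1-c1ccc(C(N)=O)cc1`, 80.8 nM
compound 2 `Cn1nc2c(=O)n(CC3(O)CCN(Cc4ccc(-c5ccco5)cc4Cl)CC3)cnc2c1-c1ccc(OC(F)F)cc1`, 179 nM
compound 3 `Cn1nc2c(=O)n(CC3(O)CCN(Cc4ccc(-c5ccsc5)cc4Cl)CC3)cnc2c1-c1ccc(CN)cc1`, 59.5 nM

Compound 3 has the lowest of the three numbers. Its nearest neighbour is compound 1, whose value lies within the scatter of that of compound 3, so no order between these two can be read. Compound 2 sits furthest away, with a value beyond the scatter from compound 3. Among the compounds with values here, the one single-point step in the set, a 2.2-fold higher number from compound 1 to compound 2 (0.35 log units; beyond the scatter), concerns the aryl group on the shared core, not the benzyl arm, and so does not bear on the change examined here. Compounds 1 and 3 differ in two places at once; their values only show that both lie close together.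

Compound 4 `Cn1nc2c(=O)n(CC3(O)CCN(Cc4ccc(C5CCCO5)cc4Cl)CC3)cnc2c1-c1ccc(CN)cc1` differs from compound 3 by oxolan-2-yl in place of thiophen-3-yl on an aromatic carbon. Within the data shown here, no measured pair isolates this position, so the expectation rests on the closeness of all three values and on the change itself. A modest drift toward a higher number is considered possible but not established, and the expected step is a 1.6-fold higher number from compound 3 to compound 4 (0.20 log units; within the scatter), which stays inside the usual scatter. For compound 4 the estimated value in this assay is 95 nM, with a range from 40 nM to 250 nM.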

Compound 4, half-maximal inhibitory concentration: 3820 nM
Compound 4: middle estimate off by 40-fold (1.60 log units), on the low side, and the stated range ends below it.
By their numbers in this assay, from the lowest: compounds 3 and 1 (each within the scatter of the next); then compound 2; then compound 4.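

In this assay, within the data shown here, the position on the benzyl arm para to a large group and meta to a chloro group proves highly sensitive: oxolan-2-yl in place of thiophen-3-yl gives a 64-fold higher number from compound 3 to compound 4 (1.81 log units; beyond the scatter), far larger than the only earlier step, a 2.2-fold higher number from compound 1 to compound 2 (0.35 log units; beyond the scatter), which lies on the aryl group of the shared core. The two groups match in heavy-atom count, ring size, hydrogen-bond donors, hydrogen-bond acceptors and net charge, yet they differ in a five-membered aromatic against a non-aromatic ring, in sulfur against oxygen, and in the point of attachment named by each group, and this single step does not separate these differences. No measurement is at hand that accounts for the loss.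

Open, from the compounds shown here alone, is which of these differences carries the step: a cyclopentyl group, an oxolan-3-yl group or a thiophen-2-yl group at this position would each change only part of them. Also open, going by these compounds, is how a furan-2-yl group compares with thiophen-3-yl here, with the aryl group of the shared core held constant.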